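The source may report more compounds than this note shows. Statements on the series, on what has been measured and on what is new or still open speak of the compounds shown alone.

Measured so far in an ADME assay on Caco-2 cells (Homo sapiens) for permeability, in the apical to basolateral direction; a lower number here means that the compound crosses the layer more slowly, a higher number that the compound crosses the layer faster:
compound 1 `Cn1cncc1CN1CC(N(CC2CCN(C(=O)c3ccc(Cl)cc3)CC2)S(=O)(=O)c2ccccn2)Cc2cc(C#N)ccc21` — 0.5 10^-6 cm/s
compound 2 `Cn1cncc1CN1CC(N(CC2CCN(C(=O)Nc3ccc(Br)cc3)CC2)S(=O)(=O)c2ccccn2)Cc2cc(C#N)ccc21` — 0.6 10^-6 cm/s
compound 3 `CCCC(=O)N1CCC(CN(C2Cc3cc(C#N)ccc3N(Cc3cncn3C)C2)S(=O)(=O)c2ccccn2)CC1` — 0.5 10^-6 cm/s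

Compound 2 holds the highest of the three numbers, but only nominally: a 1.2-fold higher number from compound 1 to compound 2 (0.08 log units; within the scatter) and a 1.2-fold lower number from compound 2 to compound 3 (0.08 log units; within the scatter) both lie within the scatter, as does no change at the digits printed from compound 1 to compound 3 (within the scatter). Compound 4 `CCOC(=O)N1CCC(CN(C2Cc3cc(C#N)ccc3N(Cc3cncn3C)C2)S(=O)(=O)c2ccccn2)CC1` has not yet been measured. It differs from compound 2 at the carbonyl carbon: ethoxy in place of (4-bromophenyl)amino on a carbonyl carbon. All three measured steps concern exchanges at that same carbonyl carbon, and none of them moved the number beyond the scatter, so no step beyond the scatter is expected here either. Compound 4 is therefore estimated at 0.5 10^-6 cm/s, with a range from 0.3 10^-6 cm/s to 1 10^-6 cm/s, which is expected to amount to a 1.2-fold lower number from compound 2 to compound 4 (0.08 log units; within the scatter).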

Compound 4, apparent permeability: 2.6 10^-6 cm/s
Beside the measured number, compound 4's estimate is 5.2-fold (0.72 log units) below it; measured number above the stated range.
By their numbers in this assay, from the lowest: compounds 1, 3 and 2 (each within the scatter of the next); then compound 4.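

In this assay, the carbonyl carbon turned out to be a place where the number can move: ethoxy gave a 4.3-fold higher number from compound 2 to compound 4 (0.64 log units; beyond the scatter) and a 5.2-fold higher number from compound 3 to compound 4 (0.72 log units; beyond the scatter) and also a 5.2-fold higher number from compound 1 to compound 4 (0.72 log units; beyond the scatter) in this series, whereas exchanges among 4-chlorophenyl, (4-bromophenyl)amino and propyl had stayed within the scatter. Ethoxy alone among these groups joins the carbonyl carbon through oxygen. Nothing available accounts for this rise.

As far as these compounds go, whether the rise is particular to ethoxy remains open. Methoxy, a longer chain such as butoxy, or a simple alkyl amine at this carbonyl carbon could settle that.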